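Trifluoromethyl for bromo: next step in the series

A few compounds are considered here, and "the series" means these few. Any claim that something is new, unique, unknown or untested is made for them only; others in the source may bear on it.

Among the measured compounds shown here, compound 2 `O=C(Nc1cccc(/C=C/C(=O)c2nc3ccccc3[nH]2)c1)c1cccc(Br)c1` gives 4620 nM in a functional assay on 143B cells (Homo sapiens) for antiproliferative activity, read by MTT assay, with a stated time of 48 h (a lower number here means a stronger inhibitor, a higher number a weaker inhibitor), the highest of the two numbers so far; its nearest neighbour is compound 1 `O=C(/C=C/c1cccc(NC(=O)c2ccccc2Cl)c1)c1nc2ccccc2[nH]1` at 3690 nM, a gap within the scatter. Compound 3 `O=C(Nc1cccc(/C=C/C(=O)c2nc3ccccc3[nH]2)c1)c1cccc(C(F)(F)F)c1` differs from compound 2 by trifluoromethyl in place of bromo on an aromatic carbon. For the measured compounds named here, the one measured step, a 1.3-fold higher number from compound 1 to compound 2 (0.10 log units; within the scatter), swaps one halophenyl for another and stays within the scatter. Going by the values given here, no step involving trifluoromethyl exists, so the expectation rests on compound 2 alone, with no change beyond the scatter expected, a 1.0-fold lower number from compound 2 to compound 3 (0.01 log units; within the scatter). Compound 3 is estimated at 4500 nM, range 2000 nM to 10000 nM.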

Compound 3, half-maximal inhibitory concentration: 9570 nM
For compound 3 the middle estimate is 2.1-fold (0.33 log units) below the measured one, and the stated range covers the measured number.
By their numbers in this assay, from the lowest: compounds 1 and 2 (each within the scatter of the next); then compound 3.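

In this assay, among the compounds shown here, trifluoromethyl in place of bromo gives a 2.1-fold higher number from compound 2 to compound 3 (0.32 log units; beyond the scatter), the first step at this aromatic carbon to pass the scatter, so this position is not indifferent to the group it carries. The change from the 2-chlorophenyl group to the 3-(trifluoromethyl)phenyl group runs the same way, with a 2.6-fold higher number from compound 1 to compound 3 (0.41 log units; beyond the scatter), and both steps are modest. Nothing available explains this rise. Going by these compounds, whether an amine or a carboxylic acid at this position would lower the number remains open, and so does whether any group here can bring it beyond the scatter below compound 1.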